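The compounds below may be only part of what the source reports. "The series", "measured", "known", "first", "only" and "open" are said of these compounds alone.

Going by the values given here, in a functional assay on A549 cells (Homo sapiens) for inhibition, read by sulforhodamine B assay, with a stated time of 72 h (on this read-out lower numbers stand for stronger inhibition and higher numbers for weaker inhibition), compound 2 `COc1ccc(CN(Cc2ccc([N+](=O)[O-])cc2)Cc2c(O)ccc3c(=O)cc(C)oc23)cc1` gives 24.5 ug/mL, the highest number of the three compounds measured so far and so the weakest inhibition among them. Compound 1 `Cc1cc(=O)c2ccc(O)c(CN(Cc3ccccc3)Cc3ccccc3)c2o1` gives 11.9 ug/mL, and compound 3 `COc1ccc(CN(Cc2ccc3ccccc3c2)Cc2c(O)ccc3c(=O)cc(C)oc23)cc1` gives 6.01 ug/mL. Compound 4 `COc1ccc(CN(Cc2ccc(OC)cc2)Cc2c(O)ccc3c(=O)cc(C)oc23)cc1` has not yet been measured and differs from compound 2 in one place: methoxy in place of nitro on an aromatic carbon, para to a large group, which turns 4-nitrobenzyl into 4-methoxybenzyl (methoxy in place of nitro on an aromatic carbon).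

Among the compounds with values here, only one measured step bears directly on this change, a 4.1-fold lower number from compound 2 to compound 3 (0.61 log units; beyond the scatter), where naphthalen-2-yl takes the place of 4-nitrophenyl. Compound 1 also lacks the nitro and shows a lower number than compound 2. Within the data shown here, no measured pair swaps nitro for methoxy itself, and a single step is thin evidence. Among the measured compounds shown here, a modest move in the same direction therefore seems likely, probably smaller than the one seen with compound 3, and no change beyond the scatter remains possible. The expected step is a 2.2-fold lower number from compound 2 to compound 4 (0.35 log units; beyond the scatter). In this assay, the estimate for compound 4 is 11 ug/mL, with an expected range from 5 ug/mL to 24 ug/mL.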

Compound 4, half-maximal inhibitory concentration: 62.5 ug/mL
Compound 4: the middle estimate sits 5.7-fold (0.75 log units) below what was measured; measured number outside the range, above it.
By their numbers in this assay, from the lowest: compounds 3 and 1 (each within the scatter of the next); then compound 2; then compound 4.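

In this assay, the change from 4-nitrobenzyl to 4-methoxybenzyl gives a 2.6-fold higher number from compound 2 to compound 4 (0.41 log units; beyond the scatter), so losing the nitro does not by itself lower the number. The earlier step, in which naphthalen-2-yl replaced 4-nitrophenyl, could not show this, since it changed the whole aromatic group and left open whether the lower number came from removing the nitro or from adding naphthalen-2-yl. The same position also spans a wide range, with a 10-fold higher number from compound 3 to compound 4 (1.02 log units; beyond the scatter), so among these three compounds, which share the other 4-methoxybenzyl arm, the number depends strongly on the group placed here, and the order is naphthalen-2-yl, then 4-nitrophenyl, then 4-methoxyphenyl. No measurement shown gives a reason for this order.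

From the compounds shown here alone, it remains open whether the higher number belongs to methoxy specifically or would also appear with other groups on the same aromatic carbon, such as an amine, a carboxylic acid or a longer alkoxy chain. It is also unknown whether the order of these three groups would hold if the other arm were something other than 4-methoxybenzyl, such as a plain benzyl.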